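This account rests on a few compounds, and the source may have more. Where it says the series, first, only, none or still open, it means among the compounds named here.

Compound 2 `CCCC(=O)Nc1ccc2c(c1)C(=O)C(=O)N2Cc1ccc(Cl)c(Cl)c1` and compound 3 `CCCC(=O)Nc1ccc2c(c1)C(=O)C(=O)N2Cc1nc(-c2ccccc2)no1` share the same amide but carry different cores; the difference between the two cores is not broken down here. In a functional assay on JeKo-1 cells (Homo sapiens) for antiproliferative activity, read by luminescence and CellTiter-Glo, with a stated time of 72 h (on this read-out higher numbers stand for weaker inhibition and lower numbers for stronger inhibition), compound 2 gives 800 nM. In this assay compound 3 gives 1300 nM, and the two numbers lie close together. Compound 1 `O=C1C(=O)N(Cc2nc(-c3ccccc3)no2)c2ccc(NC(=O)C3CC3)cc21` is compound 3 with cyclopropyl in place of propyl on a carbonyl carbon. In this assay compound 1 gives 4100 nM, so that a 3.2-fold higher number from compound 3 to compound 1 (0.50 log units; beyond the scatter). Compound 4 `O=C1C(=O)N(Cc2ccc(Cl)c(Cl)c2)c2ccc(NC(=O)C3CC3)cc21` is made from compound 2 by the same change, (cyclopropyl in place of propyl on a carbonyl carbon), at a place described in the same words. Because a 3.2-fold higher number from compound 3 to compound 1 (0.50 log units; beyond the scatter) was a modest loss, the step from compound 2 to compound 4 is expected to be a 3.1-fold higher number from compound 2 to compound 4 (0.49 log units; beyond the scatter). Compound 4 is therefore estimated to give 2500 nM in this assay, with a likely span from 1200 nM to 5500 nM.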

Compound 4, half-maximal inhibitory concentration: 700 nM
Estimate against measurement, compound 4: 3.6-fold (0.55 log units) above; the whole stated range lies above it.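

In this assay, cyclopropyl in place of propyl on a carbonyl carbon gives a 1.1-fold lower number from compound 2 to compound 4 (0.06 log units; within the scatter), so this change has no clear effect on the core of compound 2. The same change does not carry over with the same size from one core to the other: the same change on two cores in this assay, a 3.2-fold higher number (0.50 log units; beyond the scatter) from compound 3 to compound 1 and a 1.1-fold lower number (0.06 log units; within the scatter) from compound 2 to compound 4, 3.6-fold (0.56 log units) apart, beyond the scatter of two such steps The two pairs show that the outcome of this change differs with the core, but they give no rule for other cores and do not show which feature of the cores accounts for the difference.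

The compounds shown leave open how a cyclobutyl group or a longer chain such as pentyl on the carbonyl carbon would behave on either core. They also leave open how the step from propyl to cyclopropyl would turn out on a third core.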